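Swapping methyl for methoxy on an aromatic carbon

The compounds below may be only part of what the source reports. "The series", "measured", "known", "first", "only" and "open" are said of these compounds alone.

Compound 1 (`COc1ccc(OC)c(C(=O)/C=C/c2ccc(C)o2)c1`): 26500 nM
Compound 2 (`COc1ccc(OC)c(C(=O)/C=C/c2ccc(OC(=O)/C=C/c3ccc(C)cc3)cc2)c1`): 29000 nM

In a functional assay on Hep 3B2 cells (Homo sapiens) for cytotoxicity, read by MTT assay (a higher number here means a weaker inhibitor, a lower number a stronger inhibitor), compound 2 (29000 nM) and compound 1 (26500 nM) lie within the usual scatter of each other. Compound 3 (`COc1ccc(/C=C/C(=O)Oc2ccc(/C=C/C(=O)c3cc(OC)ccc3OC)cc2)cc1`) carries methoxy in place of methyl on an aromatic carbon, para to a large group (methoxy in place of methyl on an aromatic carbon). The same difference reads 4-methylphenyl to 4-methoxyphenyl. Going by the values given here, no measured pair of compounds shows what this change does, so no shift beyond the scatter is expected in this assay. The expected change is small (a 1.1-fold lower number from compound 2 to compound 3 (0.03 log units; within the scatter)). Compound 3 is estimated at 27000 nM (range 11000 nM to 60000 nM).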

Compound 3, half-maximal inhibitory concentration: 42600 nM
Compound 3: the middle estimate sits 1.6-fold (0.20 log units) below what was measured, within the range that was stated.
By their numbers in this assay, from the lowest: compounds 1, 2 and 3 (each within the scatter of the next).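

Going by these compounds alone, this is the first measured pair for methoxy in place of methyl on an aromatic carbon, para to a large group. The swap gives a 1.5-fold higher number from compound 2 to compound 3 (0.17 log units; within the scatter) in this assay, so 4-methylphenyl and 4-methoxyphenyl cannot be told apart at this position in this pair. No measurement on hand offers an explanation for this result. Still open, as far as these compounds go, is whether an amine, a carboxylic acid or a longer chain such as ethoxy at this position would move the number beyond the scatter.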